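From Compound 2 to Compound 3 in an Antiproliferative Assay

A few compounds are considered here, and "the series" means these few. Any claim that something is new, unique, unknown or untested is made for them only; others in the source may bear on it.

compound 1 `Nc1ccc(CNC(=O)Nc2ccc(CN3C(=O)c4ccccc4C3=O)cc2)cn1` — 100 nM
compound 2 `O=C(Nc1ccc(CN2C(=O)c3ccccc3C2=O)cc1)[C@H]1C[C@@H]1c1cccnc1` — 27 nM

In a functional assay on A2780 cells (Homo sapiens) for antiproliferative activity, read by CellTiter-Glo, with a stated time of 72 h (on this read-out higher numbers stand for weaker inhibition and lower numbers for stronger inhibition), compound 2 gives 27 nM, the lowest of the two numbers measured, and compound 1 gives 100 nM. Going by the values given here, the single measured step, a 3.7-fold lower number from compound 1 to compound 2 (0.57 log units; beyond the scatter), sits on the same carbonyl carbon but swaps a different pair of groups, so it bears only loosely on what follows. Compound 3 `O=C(Nc1ccc(CN2C(=O)c3ccccc3C2=O)cc1)N1CC(c2cccnc2)C1` differs from compound 2 by a group of 10 heavy atoms (8 carbon, 2 nitrogen; one four-membered non-aromatic ring with 1 hetero atom, one six-membered aromatic ring with 1 hetero atom) in place of a group of 9 heavy atoms (8 carbon, 1 nitrogen; one three-membered non-aromatic ring of carbon only, one six-membered aromatic ring with 1 hetero atom), on a carbonyl carbon. Among the compounds with values here, with no matching step measured, a modest move toward a higher number is expected: a 2.2-fold higher number from compound 2 to compound 3 (0.35 log units; beyond the scatter). Compound 3 is therefore estimated at 60 nM, within 20 nM to 200 nM.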

Compound 3, half-maximal inhibitory concentration: 5 nM
For compound 3 the middle estimate is 12-fold (1.08 log units) above the measured one; measured number outside the range, below it.
By their numbers in this assay, from the lowest: compound 3; then compound 2; then compound 1.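

At this carbonyl carbon, the group with the four-membered non-aromatic ring with 1 hetero atom gives the lowest number of the three in this assay, with a 5.4-fold lower number from compound 2 to compound 3 (0.73 log units; beyond the scatter) and a 20-fold lower number from compound 1 to compound 3 (1.30 log units; beyond the scatter). The position therefore allows a further drop beyond the one first seen with the three-membered ring of carbon only. No measurement offered here accounts for this drop. The compounds shown leave open how a five-membered pyrrolidine ring or an open-chain amine would fare on this carbonyl carbon. They also cannot separate the effect of ring size from that of the added ring nitrogen.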